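The source may hold more compounds than are shown below. What is called first, only, known or untested is meant among the compounds shown, and "the series" means these compounds.

Measured so far in a functional assay on U-87MG ATCC cells (Homo sapiens) for antiproliferative activity, read by MTT assay, with a stated time of 48 h; on this read-out higher numbers stand for weaker inhibition and lower numbers for stronger inhibition: compound 1 `COc1cc(-c2nn(-c3ccccc3)cc2C(=O)/C=C\Nc2ccc(F)cc2)cc(OC)c1OC` gives 4780 nM; compound 2 `COc1ccc(N/C=C\C(=O)c2cn(-c3ccccc3)nc2-c2cc(OC)c(OC)c(OC)c2)cc1` gives 12800 nM.

Compound 2 stands at the higher of the two numbers, compound 1 being the only comparator. Going by the values given here, the one measured step, a 2.7-fold higher number from compound 1 to compound 2 (0.43 log units; beyond the scatter), swaps a different group on the same ring and so bears only indirectly on the next change. Compound 3 `COc1cc(N/C=C\C(=O)c2cn(-c3ccccc3)nc2-c2cc(OC)c(OC)c(OC)c2)cc(OC)c1OC` differs from compound 2 by 3,4,5-trimethoxyphenyl in place of 4-methoxyphenyl on an amine nitrogen. Among the compounds with values here, no measured step tests this exact change, so the direction is open; a modest rise is nevertheless expected, a 1.6-fold higher number from compound 2 to compound 3 (0.19 log units; within the scatter). Compound 3 is estimated at 20000 nM, with a range from 6000 nM to 60000 nM.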

Compound 3, half-maximal inhibitory concentration: 5100 nM
Beside the measured number, compound 3's estimate is 3.9-fold (0.59 log units) above it; the whole stated range lies above it.
By their numbers in this assay, from the lowest: compounds 1 and 3 (each within the scatter of the next); then compound 2.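

In this assay the step to 3,4,5-trimethoxyphenyl on the amine nitrogen gives a 2.5-fold lower number from compound 2 to compound 3 (0.40 log units; beyond the scatter) and so reverses the loss seen with 4-methoxyphenyl, which means that more methoxy groups on this ring do not simply track with a higher number. Against 4-fluorophenyl the same group gives a 1.1-fold higher number from compound 1 to compound 3 (0.03 log units; within the scatter) and is not told apart from it. Nothing at hand explains either step.

Open, on these data alone, is whether this nitrogen tolerates a group other than a substituted phenyl, such as cyclohexyl or benzyl. Also open, as far as these compounds go, is whether a single methoxy group elsewhere on the ring behaves like the 4-methoxyphenyl case.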